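Shortening the Side Chain on a Shared Core

This account rests on a few compounds, and the source may have more. Where it says the series, first, only, none or still open, it means among the compounds named here.

Among the measured compounds shown here, compound 2 `CCCCCCNc1nc2c(cc1C#N)C(=O)CC(C)(C)C2` gives 2600 nM in an in vitro functional assay on cells for antagonist activity at metabotropic glutamate receptor 1 (Rattus norvegicus), read by inositol phosphate accumulation; a lower number here means a stronger inhibitor, a higher number a weaker inhibitor; the only other number measured so far, from compound 1 `CC1(C)CC(=O)c2cc(C#N)c(NCc3ccccc3)nc2C1` at 2500 nM, sits within the scatter of it, as the step of a 1.0-fold higher number from compound 1 to compound 2 (0.02 log units; within the scatter) shows. Compound 3 `CCCNc1nc2c(cc1C#N)C(=O)CC(C)(C)C2` differs from compound 2 by hydrogen in place of propyl on a saturated chain carbon, three bonds along the chain from a nitrogen on an aromatic ring. For the measured compounds named here, no measured step shortens this chain; the one known step exchanges a ring for a chain and leaves the number unmoved. In this assay a step of no more than modest size, in either direction, is therefore expected: a 1.3-fold higher number from compound 2 to compound 3 (0.13 log units; within the scatter). Compound 3 is estimated at 3500 nM, between 1200 nM and 10000 nM.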

Compound 3, half-maximal inhibitory concentration: 2300 nM
Compound 3: the middle estimate sits 1.5-fold (0.18 log units) above what was measured; measured number inside the range.
By their numbers in this assay, from the lowest: compounds 3, 1 and 2 (each within the scatter of the next).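

In this assay, the shorter chain of compound 3 leaves the number within the scatter of the hexyl chain (a 1.1-fold lower number from compound 2 to compound 3 (0.05 log units; within the scatter)). The same holds when ethyl stands in place of phenyl (a 1.1-fold lower number from compound 1 to compound 3 (0.04 log units; within the scatter)), so at this position neither propyl against hexyl nor a chain against a phenyl-ended group separates these compounds. No measurement on hand explains this result. Still open, going by these compounds, is whether an amine or a carboxylic acid on the chain, or a chain longer than hexyl, would move the number beyond the scatter.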